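This account rests on a few compounds, and the source may have more. Where it says the series, first, only, none or still open, it means among the compounds named here.

Measured compounds:
Compound 1 `Cc1cc(C)c(NC(=O)Nc2ccncc2)c(C)c1` gives 30 mg/kg in a functional assay on the whole organism with Mus musculus as the target, in the maximal electroshock model, with a stated time of 30 min; on this read-out lower numbers stand for an effect already at smaller amounts and higher numbers for an effect only at larger amounts of compound.
Compound 2 `Cc1cc(C)c(NC(=O)Nc2ccncc2)c(Cl)c1` gives 100 mg/kg in this assay.
Compound 3 `O=C(Nc1cccnc1)Nc1c(Cl)cccc1Cl` gives only a limit in this assay, > 300 mg/kg, which is a limit of the assay and not a number.

Compound 1 and compound 2 share a core and differ in one place: methyl in place of chloro on an aromatic carbon. This change brought a 3.3-fold lower number from compound 2 to compound 1 (0.52 log units; beyond the scatter). The difference between the core of compound 3 and the core of compound 2 is not broken down here. Compound 4 `Cc1cccc(Cl)c1NC(=O)Nc1cccnc1` has not yet been measured in this assay; it differs from compound 3 by methyl in place of chloro on an aromatic carbon. The two changes are the same kind of change, but the surroundings differ: in compound 1 the place is meta to two methyl groups, while in compound 4 it is meta to a chloro group. For compound 3 only a limit is known, (the limit of > 300 mg/kg in this assay, at which 1 of the 3 values shown sits), so the starting point of the new step is itself uncertain. If the same kind of change acts as it did from compound 2 to compound 1, compound 4 is expected to show a number no higher from compound 3 to compound 4 (the limit leaves the size open) in this assay. Compound 4 is therefore estimated at 300 mg/kg, with a range from 100 mg/kg to 900 mg/kg.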

Compound 4, minimum effective dose: 100 mg/kg
Estimate against measurement, compound 4: 3.0-fold (0.48 log units) above; low and high end bracket the measured number.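

In this assay, methyl in place of chloro on an aromatic carbon brought an at least 3.0-fold lower number from compound 3 to compound 4 (0.47 log units; beyond the scatter), which shows that the direction of the change held on both cores shown. Set side by side, the two steps read: the same change on two cores in this assay, a 3.3-fold lower number (0.52 log units; beyond the scatter) from compound 2 to compound 1 and an at least 3.0-fold lower number (0.47 log units; beyond the scatter) from compound 3 to compound 4; the limit leaves it open whether they differ. Compound 3 gives > 300 mg/kg, which is a limit of the assay and not a number, and the data do not show how large the second step is or whether the change is worth the same on both cores.

The compounds shown carry only methyl or chloro at the place of change, which leaves open what a methoxy group, a trifluoromethyl group, an amine or a longer chain would give there. On these data alone, it also remains open whether methyl in place of chloro would bring a lower number on any core beyond these two.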